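A Swap at the Alkyne Tip of Compound 2

The source may hold more compounds than are shown below. What is called first, only, known or untested is meant among the compounds shown, and "the series" means these compounds.

Compound 1 `C#Cc1ccc2ncn(-c3ccnc(N)n3)c2c1`: 251 nM
Compound 2 `C#Cc1cncc(C#Cc2ccc3ncn(-c4ccnc(N)n4)c3c2)n1`: 6310 nM

In an assay on Sf9 cells for inhibition of mitogen-activated protein kinase kinase kinase 14 variant S549D (Homo sapiens), with a stated time of 30 min, in the presence of a further agent that is not named here (a higher number here means a weaker inhibitor, a lower number a stronger inhibitor), compound 1 gives 251 nM, while compound 2 gives 6310 nM, the highest of the two measured numbers. Within the data shown here, the single measured step, a 25-fold higher number from compound 1 to compound 2 (1.40 log units; beyond the scatter), came from attaching the whole terminal ring to the triple-bonded carbon. Compound 3 `Cc1ccnc(C#Cc2ccc3ncn(-c4ccnc(N)n4)c3c2)n1` differs from compound 2 by a group of 7 heavy atoms (5 carbon, 2 nitrogen; one six-membered aromatic ring with 2 hetero atoms) in place of a group of 8 heavy atoms (6 carbon, 2 nitrogen; one six-membered aromatic ring with 2 hetero atoms), on a triple-bonded carbon. Among the measured compounds shown here, no measured step bears directly on exchanging one such ring for another of similar size, so the analyst expects a change near the scatter, a 1.3-fold lower number from compound 2 to compound 3 (0.10 log units; within the scatter). Compound 3 is estimated at 5000 nM, within 1500 nM to 16000 nM.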

Compound 3, half-maximal inhibitory concentration: 1580 nM
Compound 3: the middle estimate sits 3.2-fold (0.50 log units) above what was measured, and the stated range covers the measured number.
By their numbers in this assay, from the lowest: compound 1; then compound 3; then compound 2.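

At this triple-bonded carbon the identity of the ring matters: in this assay, 4-methylpyrimidin-2-yl in place of the other ring of similar size gives a clear change (a 4.0-fold lower number from compound 2 to compound 3 (0.60 log units; beyond the scatter)). Even so, this ring still falls short of the terminal hydrogen (a 6.3-fold higher number from compound 1 to compound 3 (0.80 log units; beyond the scatter)), so both rings shown give higher numbers than the hydrogen does. Nothing at hand accounts for the difference between the two rings.

On these data alone, whether a phenyl ring or an aminomethyl group at this carbon would come closer to the hydrogen remains open. So does whether the methyl of 4-methylpyrimidin-2-yl contributes to the lower number.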